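A few compounds are considered here, and "the series" means these few. Any claim that something is new, unique, unknown or untested is made for them only; others in the source may bear on it.

Measured compounds in a functional assay on MDA-MB-231 cells (Homo sapiens) for antiproliferative activity, read by MTT assay, with a stated time of 72 h; a lower number here means a stronger inhibitor, a higher number a weaker inhibitor:
- compound 1, `CCN(CC)C(=S)SSC1CCCCC1`: 960 nM
- compound 2, `CCN(CC)C(=S)SSC(C)C`: 960 nM
- compound 3, `CCN(CC)C(=S)SSc1ccc(C(=O)O)cc1`: 6300 nM

Three dithiocarbamate disulfides have been measured. Compound 2 and compound 1 stand level with each other at the digits shown, within the scatter, and together they give the two lowest numbers of the three; the set is too small to call either one the strongest. Compound 3 gives a clearly higher number, beyond the scatter, as its value above shows.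

The next compound is compound 4, `CCN(CC)C(=S)SSCCO`, not yet measured. Its difference from compound 2 is 2-hydroxyethyl in place of isopropyl on a sulfur. Among the compounds with values here, no step between two measured compounds isolates this kind of exchange, so the direction rests on little. Within the data shown here, compound 3, the only measured member carrying a hydrogen-bond donor and acceptor on the group that leaves the disulfide, gives 6300 nM, but it also differs from compound 2 in the ring, so it does not settle the question. For compound 4 a modest rise in number is expected, a 1.6-fold higher number from compound 2 to compound 4 (0.19 log units; within the scatter), possibly no change beyond the scatter. The estimate for compound 4 in this assay is 1500 nM, with a range from 500 nM to 5000 nM.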

Compound 4, half-maximal inhibitory concentration: 10000 nM
The estimate for compound 4 lay 6.7-fold (0.82 log units) below the measured number, outside the stated range (above it).
By their numbers in this assay, from the lowest: compounds 1 and 2 (each within the scatter of the next); then compounds 3 and 4 (each within the scatter of the next).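

In this assay, within the data shown here, 2-hydroxyethyl in place of isopropyl on a sulfur gives a 10-fold higher number from compound 2 to compound 4 (1.02 log units; beyond the scatter), the first single-place step, and it is large. The group on this sulfur therefore matters: the level numbers of compound 1 and compound 2 do not extend to every group here, even though isopropyl and 2-hydroxyethyl have the same heavy-atom count and differ in their hydrogen-bond donor and acceptor counts. Nothing at hand accounts for the size of this step.

From the compounds shown here alone, it remains open whether the step follows the hydroxyl or the loss of the branched chain, and a plain ethyl or a 2-methoxyethyl group on the same sulfur would separate the two. Going by these compounds, the reading of an amine or a carboxylic acid at the end of that chain is also open.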